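The source may report more compounds than this note shows. Statements on the series, on what has been measured and on what is new or still open speak of the compounds shown alone.

Of the compounds shown here, two have been measured so far in a functional assay on MCF-10A cells (Homo sapiens) for antiproliferative activity, with a stated time of 48 h; on this read-out higher numbers stand for an effect only at larger amounts of compound and lower numbers for an effect already at smaller amounts. Compound 1 (`CCCOc1ccc2nc(C)cc(NCc3ccc(F)cc3)c2c1`) gives 9800 nM, and compound 2 (`CCCCCCCCOc1ccc2nc(C)cc(NCc3ccc(F)cc3)c2c1`) gives 1800 nM, the lower of the two numbers and beyond the scatter of the other. Compound 3 (`CCCCCCCCCCOc1ccc2nc(C)cc(NCc3ccc(F)cc3)c2c1`) is the next to be read. Its change from compound 2 is ethyl in place of hydrogen on a saturated chain carbon, eight bonds along the chain from an oxygen on an aromatic ring, which places ethyl in place of hydrogen on a saturated chain carbon, eight bonds along the chain from an oxygen on an aromatic ring.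

Among the measured compounds shown here, only one measured step bears on this: a 5.4-fold lower number from compound 1 to compound 2 (0.74 log units; beyond the scatter), a modest drop on adding pentyl to the same chain. Ethyl is the shorter addition, and a single step cannot show whether the drop continues at this chain length. A smaller move towards a lower number in this assay is expected, near the edge of the scatter. The expected step is a 1.8-fold lower number from compound 2 to compound 3 (0.26 log units; within the scatter). For compound 3 the estimated value is 1000 nM, with an expected range from 350 nM to 3500 nM.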

Compound 3, half-maximal effective concentration: 1900 nM
Estimate against measurement, compound 3: 1.9-fold (0.28 log units) below, within the range that was stated.
By their numbers in this assay, from the lowest: compounds 2 and 3 (each within the scatter of the next); then compound 1.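

In this assay, ethyl in place of hydrogen on a saturated chain carbon, eight bonds along the chain from an oxygen on an aromatic ring, gives a 1.1-fold higher number from compound 2 to compound 3 (0.02 log units; within the scatter), so the drop seen with the earlier lengthening does not continue with this addition. The full lengthening of the chain gives a 5.2-fold lower number from compound 1 to compound 3 (0.71 log units; beyond the scatter), so the gain over the shorter chain of compound 1 is kept while compound 2 and compound 3 stay within the scatter of each other. No measurement at hand accounts for this flat reading.

From the compounds shown here alone, whether a longer chain stays level or moves the number in either direction remains open. So does the effect of an amine or a carboxylic acid carried on the chain.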